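Imine Variation on a Quinolinone-Free Core: Toward Compound 3

The source may hold more compounds than are shown below. What is called first, only, known or untested is meant among the compounds shown, and "the series" means these compounds.

Measured so far:
compound 1 `O=c1[nH]c2ccccc2cc1/C=N/Cc1ccccc1`: 368000 nM
compound 2 `N/N=C/c1cc2ccccc2[nH]c1=O`: 20600 nM

In a functional assay, read by spectrophotometry, with a stated time of 3 min (a higher number here means a weaker inhibitor, a lower number a stronger inhibitor), compound 2 gives 20600 nM, the lowest of the two numbers, while compound 1 gives 368000 nM, a gap that lies beyond the usual scatter. Compound 3 `O=c1[nH]c2ccccc2cc1/C=N/CCO` is not yet measured. It differs from compound 2 in one place: 2-hydroxyethyl in place of amino on a double-bonded nitrogen. Among the compounds with values here, no step between measured compounds in this assay matches this change, so the expected size is uncertain. Because compound 1 gives 368000 nM, a step toward weaker inhibition from compound 2 is expected, a 4.9-fold higher number from compound 2 to compound 3 (0.69 log units; beyond the scatter). Compound 3 is estimated at 100000 nM, between 25000 nM and 400000 nM.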

Compound 3, half-maximal inhibitory concentration: 1210000 nM
Estimate against measurement, compound 3: 12-fold (1.08 log units) below; the whole stated range lies below it.
By their numbers in this assay, from the lowest: compound 2; then compound 1; then compound 3.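

In this assay the group on the double-bonded nitrogen proves decisive, as 2-hydroxyethyl in place of amino gives a 59-fold higher number from compound 2 to compound 3 (1.77 log units; beyond the scatter) and marks a large step. Hydroxymethyl in place of phenyl on the saturated chain carbon gives a 3.3-fold higher number from compound 1 to compound 3 (0.52 log units; beyond the scatter) as a modest step, so both carbon-bound chains lie well above amino, and compound 3 is the weakest of the three. No measurement shown accounts for these steps. On these data alone, whether an ethyl group, a longer chain or a carboxylic acid on this nitrogen would stand closer to compound 2 or to compound 3 remains open.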